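Hydroxy added to the 1,2-dimethylpropyl chain

The compounds below may be only part of what the source reports. "The series", "measured", "known", "first", "only" and "open" are said of these compounds alone.

Going by the values given here, in a functional assay on HL-60 cells (Homo sapiens) for cytotoxicity, read by WST assay, with a stated time of 48 h (on this read-out lower numbers stand for stronger inhibition and higher numbers for weaker inhibition), only two compounds have numbers so far. Compound 1 `COC[C@H](C)[C@H](C)C(c1ccc(O)c(OC)c1)c1ccc(O)c(OC)c1` gives 82000 nM, and compound 2 `COc1cc(C(c2ccc(O)c(OC)c2)[C@H](C)C(C)C)ccc1O` gives 17000 nM, the lower of the two. Among the compounds with values here, the one measured step, a 4.8-fold lower number from compound 1 to compound 2 (0.68 log units; beyond the scatter), is modest but beyond the scatter, and comes with 1,2-dimethylpropyl in place of 2-(methoxymethyl)-1-methylpropyl.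

Compound 3 `COc1cc(C(c2ccc(O)c(OC)c2)[C@H](C)[C@H](C)CO)ccc1O` has not been measured. It differs from compound 2 by hydroxy in place of hydrogen on a saturated chain carbon, four bonds along the chain from two aromatic carbons. The same difference reads as 1,2-dimethylpropyl to 2-(hydroxymethyl)-1-methylpropyl.

Within the data shown here, only the step of a 4.8-fold lower number from compound 1 to compound 2 (0.68 log units; beyond the scatter) bears on this change, since it concerns the same substituent. Read in reverse, it links the oxygen-bearing chain of compound 1 to the higher number, but a single step is thin support, and no compound with a free hydroxy has been measured. A higher number is therefore expected, with a size similar to or somewhat below that step: an estimated 2.6-fold higher number from compound 2 to compound 3 (0.42 log units; beyond the scatter). For compound 3 the expected value is 45000 nM, with an estimated range of 18000 nM to 120000 nM.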

Compound 3, half-maximal inhibitory concentration: > 100000 nM
Compound 3 ended at the assay's limit; the forecaster's own chance of this, stated with the estimate: 15%; middle value at least 2.2-fold (0.34 log units) from the limit.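

In this assay compound 3 reads > 100000 nM, which is a limit of the assay and not a number. Hydroxy in place of hydrogen on a saturated chain carbon, four bonds along the chain from two aromatic carbons, gives an at least 5.8-fold higher number from compound 2 to compound 3 (0.76 log units; beyond the scatter), so this single change at the chain end moves the number the same way as the earlier methoxymethyl comparison, and the 1,2-dimethylpropyl chain keeps the lowest number of the three. The two oxygen-bearing chain ends, hydroxymethyl and methoxymethyl, cannot be ordered, with an at least 1.2-fold higher number from compound 1 to compound 3 (0.08 log units; that floor lies within the scatter), because the reading stops at the assay's limit: the limit of > 100000 nM in this assay, at which 1 of the 3 values shown sits.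

Still open, on these data alone, is how far the number of the hydroxy compound really lies from that of the methoxymethyl compound, and with it whether the kind of oxygen group at this chain end matters at all. Also open is how an amine, a carboxylic acid, a fluorine atom or a longer carbon chain at this same place would read, since the compounds shown cover only hydrogen, hydroxy and methoxy there.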